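Replacing a benzyl with a methoxyphenoxy group: acidity expectation

The source may hold more compounds than are shown below. What is called first, only, known or untested is meant among the compounds shown, and "the series" means these compounds.

The study follows a series sharing one core, measured in a physicochemical assay for acid dissociation. Compound 1, `COc1cccc(CNCCCNc2ccnc3cc(Oc4ccccc4)ccc23)c1O`, gives 9.28. Compound 2, `COc1cccc(CNCCCNc2ccnc3cc(-c4ccc(F)cc4)ccc23)c1O`, gives 9.47, and compound 3, `COc1cccc(CNCCCNc2ccnc3cc(Cc4cc(C)cc(C)c4)ccc23)c1O`, gives 9.47. On these numbers compound 3 stands level with compound 2 at the digits shown, the two together being the highest of the three, while compound 1 lies slightly lower; the steps of a number 0.19 log units higher from compound 1 to compound 2 (within the scatter), a number 0.19 log units higher from compound 1 to compound 3 (within the scatter) and no change at the digits printed from compound 2 to compound 3 (within the scatter) all sit within the scatter of this assay, so no real order among the three can be claimed.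

Compound 4, `COc1cccc(Oc2ccc3c(NCCCNCc4cccc(OC)c4O)ccnc3c2)c1`, is not yet measured. It differs from compound 3 by 3-methoxyphenoxy in place of 3,5-dimethylbenzyl on an aromatic carbon. Within the data shown here, the step most closely related is the one from compound 1 to compound 3, where a 3,5-dimethylbenzyl replaced a phenoxy group and the reading moved by a number 0.19 log units higher from compound 1 to compound 3 (within the scatter); the step of no change at the digits printed from compound 2 to compound 3 (within the scatter) likewise showed nothing beyond the scatter. Going back toward a phenoxy-type group is therefore expected to change little, with at most a small downward drift, a number 0.17 log units lower from compound 3 to compound 4 (within the scatter). On that basis compound 4 is expected to give 9.3 in this assay, with a likely range from 9 to 9.6.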

Compound 4, acid dissociation constant: 9.28
Estimate against measurement, compound 4: 0.02 log units above; the range from low to high includes it.
By their numbers in this assay, from the lowest: compounds 1, 4, 2 and 3 (each within the scatter of the next).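

At this aromatic carbon of the shared core, 3-methoxyphenoxy brings 2 hydrogen-bond acceptors where 3,5-dimethylbenzyl and 4-fluorophenyl bring 0, yet in this assay the readings show a number 0.19 log units lower from compound 3 to compound 4 (within the scatter) and a number 0.19 log units lower from compound 2 to compound 4 (within the scatter) with no step beyond the scatter. The earlier compounds shown here held no substituent on the phenoxy ring, and methoxy in place of hydrogen on an aromatic carbon now gives no change at the digits printed from compound 1 to compound 4 (within the scatter) in this set. Across all four compounds, then, the four groups at this position give readings that no listed step separates beyond the scatter, and no compound here goes against that. No measurement shown accounts for the readings staying so close together. As far as these compounds go, whether an amine or a carboxylic acid at this aromatic carbon would move the reading in this assay beyond the scatter stays open, as does the effect of a longer chain in place of the one shared by all four compounds.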